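Naphthalen-1-yl Replaces 3-Chlorophenyl on the Benzylic Sulfur

The source may hold more compounds than are shown below. What is called first, only, known or untested is meant among the compounds shown, and "the series" means these compounds.

Measured compounds:
compound 1, `Cc1cc(S(=O)(=O)/N=C(\N)n2nccc2-c2ccccc2)c(SCc2ccc(Cl)cc2)cc1Cl`, 75000 nM
compound 2, `Cc1cccc(CSc2cc(Cl)c(C)cc2S(=O)(=O)/N=C(\N)n2nccc2-c2ccccc2)c1`, 47000 nM
compound 3, `Cc1cc(S(=O)(=O)/N=C(\N)n2nccc2-c2ccccc2)c(SCc2cccc(Cl)c2)cc1Cl`, 88000 nM

All three share one core and differ only in the group on a saturated chain carbon bound to a sulfur, or in one substituent on the aromatic ring of that group. In a functional assay on MCF7 cells (Homo sapiens) for cytotoxicity, read by MTT assay, with a stated time of 72 h (a higher number here means a weaker inhibitor, a lower number a stronger inhibitor), compound 3 gives 88000 nM, the highest of the three numbers, yet the two steps that lead to it, a 1.2-fold higher number from compound 1 to compound 3 (0.07 log units; within the scatter) and a 1.9-fold higher number from compound 2 to compound 3 (0.27 log units; within the scatter), both lie within the scatter, so no order among them can be read.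

Compound 4, `Cc1cc(S(=O)(=O)/N=C(\N)n2nccc2-c2ccccc2)c(SCc2cccc3ccccc23)cc1Cl`, continues this series. Its difference from compound 3 is naphthalen-1-yl in place of 3-chlorophenyl on a saturated chain carbon bound to a sulfur. Going by the values given here, two measured steps bear on it, since both also exchange the aryl group on that saturated chain carbon: a 1.6-fold lower number from compound 1 to compound 2 (0.20 log units; within the scatter) and a 1.2-fold higher number from compound 1 to compound 3 (0.07 log units; within the scatter). Neither reached beyond the scatter. Aryl exchange at this position has so far left the read-out unchanged within the scatter, and the entering naphthalen-1-yl gives no measured step of its own.

Compound 4 is therefore expected to show a 1.0-fold lower number from compound 3 to compound 4 (0.02 log units; within the scatter), no step beyond the scatter. The estimate for compound 4 is 85000 nM, with a range of 35000 nM to 200000 nM.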

Compound 4, half-maximal inhibitory concentration: 58000 nM
For compound 4 the middle estimate is 1.5-fold (0.17 log units) above the measured one, within the range that was stated.
By their numbers in this assay, from the lowest: compounds 2, 4, 1 and 3 (each within the scatter of the next).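

At this position on a saturated chain carbon bound to a sulfur, the exchange goes further than the earlier ones: naphthalen-1-yl, with 2 six-membered aromatic rings of carbon only and 10 heavy atoms, takes the place of single-ring groups of the kind seen so far, and the chlorine of 3-chlorophenyl leaves with the exchange. Even so, in this assay all three new comparisons stay within the scatter (a 1.5-fold lower number from compound 3 to compound 4 (0.18 log units; within the scatter); a 1.2-fold higher number from compound 2 to compound 4 (0.09 log units; within the scatter); a 1.3-fold lower number from compound 1 to compound 4 (0.11 log units; within the scatter)), so compound 4 cannot be ordered against compound 1, compound 2 or compound 3, and a second aromatic ring on this carbon, like the earlier swaps of chloro and methyl, leaves the read-out unchanged within the scatter across all four compounds, with none going against this. No measurement of any other kind is at hand to say what lies behind this flat result.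

As far as these compounds go, all four compounds carry an aromatic group on this carbon, so it remains open whether a group with an amine or a carboxylic acid, or a plain hexyl chain with no aromatic ring, would give a step beyond the scatter. From the compounds shown here alone, all four also keep the shared core unchanged, so what a change elsewhere in the molecule would do to these high numbers stays open as well.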